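A few compounds are considered here, and "the series" means these few. Any claim that something is new, unique, unknown or untested is made for them only; others in the source may bear on it.

Compound 1 `C(=C1\CCN=C1c1cccnc1)\c1ccccc1` is the starting point. In an assay for displacement of a labelled ligand from Nicotinic acetylcholine receptor alpha8 subunit (Periplaneta americana), read by scintillation counting, with a stated time of 2 h, at 24 degrees C (on this read-out higher numbers stand for weaker inhibition and lower numbers for stronger inhibition), compound 1 gives only a limit of the assay, > 10000 nM. Compound 2 `Oc1cccc(/C=C2\CCN=C2c2cccnc2)c1` differs from it by hydroxy in place of hydrogen on an aromatic carbon. In this assay compound 2 likewise gives only a limit, > 10000 nM. The step that the two limits leave unreadable from compound 1 to compound 2 cannot be sized, since (the limit of > 10000 nM in this assay, at which 2 of the 2 values shown sit). Compound 3 `Oc1ccccc1/C=C1\CCN=C1c1cccnc1` differs from compound 1 by hydroxy in place of hydrogen on an aromatic carbon. Among the measured compounds shown here, the one measured step of the same kind, from compound 1 to compound 2, is unreadable, so it supports no direction and no size for the step in this assay; both values simply sit at the limit. Compound 3 is therefore expected to show a step that the limit leaves unreadable from compound 1 to compound 3, not beyond the scatter. For compound 3 the estimate in this assay is 15000 nM, with a range from 5000 nM to 50000 nM, and a limit rather than a number is the likelier report.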

Compound 3, half-maximal inhibitory concentration: 6900 nM
Compound 3: middle estimate off by 2.2-fold (0.34 log units), on the high side; low and high end bracket the measured number.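

Among the compounds shown here, with hydroxy ortho to a large group, compound 3 is the only one of the three compounds to give a number rather than a limit in this assay (6900 nM). Compound 2, which carries the same hydroxy at another place on the ring, gives only a limit of the assay (> 10000 nM). The change at this place can be read as an at least 1.4-fold lower number from compound 1 to compound 3 (0.16 log units; that floor lies within the scatter) and no more closely, because compound 1 has only a limit: the limit of > 10000 nM in this assay, at which 2 of the 3 values shown sit.

The compounds shown leave open how far the number lies from that of compound 1, and so whether the step exceeds the scatter. They also leave open whether a methoxy group, an amine or a fluorine at this same place would give a number at all.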